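Chloro at the pendant phenyl: a short step on the quinoline amide

The compounds below may be only part of what the source reports. "The series", "measured", "known", "first", "only" and "open" are said of these compounds alone.

Of the compounds shown here, two share one amide scaffold and have been tested in a functional assay on HT-29 cells (Homo sapiens) for cytotoxicity, read by MTT assay, with a stated time of 72 h; a lower number here means a stronger inhibitor, a higher number a weaker inhibitor. Compound 1, `COc1cc2c(Oc3ccc(NC(=O)c4cc(-c5cccc(Cl)c5)nc5ccc(F)cc45)cc3F)ccnc2cc1OCCCN1CCC(C)CC1`, gives 92 nM. Compound 2, `COc1cc2c(Oc3ccc(NC(=O)c4cc(-c5ccccc5)nc5ccc(F)cc45)cc3F)ccnc2cc1OCCCN1CCCC1`, gives 160 nM. Compound 2 thus holds the higher of the two numbers, but its nearest neighbour, compound 1, sits within the scatter of it, so the two values cannot be told apart with any confidence.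

Compound 3, `COc1cc2c(Oc3ccc(NC(=O)c4cc(-c5cccc(Cl)c5)nc5ccc(F)cc45)cc3F)ccnc2cc1OCCCN1CCCC1`, has not yet been measured in this assay. It differs from compound 2 in one place only: chloro in place of hydrogen on an aromatic carbon. Read one bond further out, the change is phenyl to 3-chlorophenyl, and the place is an aromatic carbon of a six-membered aromatic ring of carbon only.

Among the compounds with values here, no measured pair in this set isolates that change, so there is no step to lean on. On the evidence of the two values shown, the step from compound 2 to compound 3 in this assay is expected to be small, a 1.5-fold lower number from compound 2 to compound 3 (0.16 log units; within the scatter), and not beyond the scatter in either direction. Compound 3 is therefore estimated at 110 nM, with a range from 40 nM to 300 nM.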

Compound 3, half-maximal inhibitory concentration: 670 nM
The estimate for compound 3 lay 6.1-fold (0.78 log units) below the measured number; measured number above the stated range.
By their numbers in this assay, from the lowest: compounds 1 and 2 (each within the scatter of the next); then compound 3.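

In this assay, within the data shown here, the single change at this aromatic carbon can now be read for the first time, and it goes the wrong way: chloro in place of hydrogen gives a 4.2-fold higher number from compound 2 to compound 3 (0.62 log units; beyond the scatter), beyond the scatter, so with pyrrolidin-1-yl at the chain end this one added heavy atom yields a weaker inhibitor. The result also shows that the chain end matters when 3-chlorophenyl is held fixed: pyrrolidin-1-yl in place of 4-methylpiperidin-1-yl, on a saturated chain carbon, gives a 7.3-fold higher number from compound 1 to compound 3 (0.86 log units; beyond the scatter), again beyond the scatter. No measurement shown here accounts for either step.

From the compounds shown here alone, whether chloro carries the same penalty with 4-methylpiperidin-1-yl at the chain end stays open: the step from phenyl to 3-chlorophenyl can be read only with pyrrolidin-1-yl. Also open, going by these compounds, is how a fluoro, a methoxy or a nitrile would read on the same aromatic carbon, and whether a morpholine at the chain end would fall nearer to pyrrolidin-1-yl or to 4-methylpiperidin-1-yl.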